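From Chloro to Hydroxy: Compound 2 to Compound 3

The compounds below may be only part of what the source reports. "The series", "measured", "known", "first", "only" and "open" are said of these compounds alone.

Compound 2 `N#Cc1c(Nc2ccc(Cl)cc2)nc(SCC(=O)Nn2c(COc3ccc(Cl)cc3Cl)nc3ccccc3c2=O)nc1-c1ccccc1` was tested in a functional assay on the whole organism (strain albino) for inhibition, with Rattus norvegicus as the target, read by paw edema, with stated times of 1 h and 0.5 h, at a dose of 100 mg/kg by the oral route (on this read-out lower numbers stand for less inhibition and higher numbers for more inhibition at the one dose given (going by the name of the read-out)), where compound 2 gives 51.9%. Of the two measured numbers it reads lowest, but its partner compound 1 `N#Cc1c(Cl)nc(SCC(=O)Nn2c(COc3ccc(Cl)cc3Cl)nc3ccccc3c2=O)nc1-c1ccccc1` gives 53.9%, and the step of a number 2 percentage points lower from compound 1 to compound 2 (within the scatter) lies within the scatter, so the two stand level. Compound 3 `N#Cc1c(Nc2ccc(O)cc2)nc(SCC(=O)Nn2c(COc3ccc(Cl)cc3Cl)nc3ccccc3c2=O)nc1-c1ccccc1` differs from compound 2 by hydroxy in place of chloro on an aromatic carbon. Within the data shown here, the only measured step bearing on this change, a number 2 percentage points lower from compound 1 to compound 2 (within the scatter), also altered that aromatic carbon and stayed within the scatter. Compound 3 is therefore expected to show a number 0.1 percentage points higher from compound 2 to compound 3 (within the scatter), nothing beyond the scatter. Compound 3 is estimated at 52%, between 40% and 64%.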

Compound 3, a percentage reported as inhibition, in the whole organism at one dose (the size of the read-out at that dose, not a potency): 61.5%
Beside the measured number, compound 3's estimate is 9.5 percentage points below it; the range from low to high includes it.
By their numbers in this assay, from the lowest: compounds 2, 1 and 3 (each within the scatter of the next).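

In this assay, hydroxy in place of chloro on the aromatic carbon para to a large group gives a number 9.6 percentage points higher from compound 2 to compound 3 (within the scatter), so this position accepts a group with a hydrogen-bond donor and acceptor without leaving the scatter. The whole (4-hydroxyphenyl)amino group in place of chloro gives a number 7.6 percentage points higher from compound 1 to compound 3 (within the scatter), also within the scatter. Nothing at hand explains these readings. Going by these compounds, whether an amine or a methoxy group at this position would stay within the scatter remains open, and so does the read-out at any other dose.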